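The compounds below may be only part of what the source reports. "The series", "measured", "known", "first", "only" and "open" are said of these compounds alone.

Working notes on the series, read in an ADME assay on J774.1 cells (Mus musculus) for cytotoxicity, read by resazurin assay, with a stated time of 48 h; a lower number here means a stronger inhibitor, a higher number a weaker inhibitor. Compound 2 `CCn1cc(C(=O)O)c(=O)c2ccc(C(F)(F)F)cc21` gives > 100000 nM, which is a limit of the assay and not a number. Compound 1 `CCn1cc(C(=O)NCc2ccc(OC)cc2)c(=O)c2ccc(C(F)(F)F)cc21` gives > 100000 nM, which is also a limit. Compound 3 `CCCCn1cc(C(=O)NCc2ccccc2)c(=O)c2cc(F)c(N(C)Cc3ccccc3)cc21` gives 86000 nM, the only result of the three reported as a number. Compound 2 therefore stands at the limit of > 100000 nM in this assay, at which 2 of the 3 values shown sit.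

The next compound to read is compound 4 `CCn1cc(C(=O)Nc2ccc(Cl)c(F)c2)c(=O)c2ccc(C(F)(F)F)cc21`, which differs from compound 2 at one place: (4-chloro-3-fluorophenyl)amino in place of hydroxy on a carbonyl carbon. In words, (4-chloro-3-fluorophenyl)amino stands in place of hydroxy on a carbonyl carbon.

Going by the values given here, no measured single-place step is available in this assay to size this change, and a limit gives only one side of any comparison. The expectation is a small step at most, in the direction of a lower number and so of a stronger inhibitor. Among the compounds with values here, it rests on compound 3 at 86000 nM, the one measured compound with a number, and remains weakly supported. A result reported only as a limit would fit the expectation equally well.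

This amounts to an expected at least 1.6-fold lower number from compound 2 to compound 4 (0.22 log units; that floor lies within the scatter). For compound 4 the estimated value is 60000 nM, with an expected range of 20000 nM to 100000 nM.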

Compound 4, half-maximal inhibitory concentration: > 100000 nM
Compound 4 ended at the assay's limit; the forecaster's own chance of this, stated with the estimate: 50%; middle value at least 1.6-fold (0.22 log units) away from the limit.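

Compound 4 gives > 100000 nM, which is a limit and not a number. With limits at both ends, neither the step from compound 2 to compound 4 nor the step from compound 1 to compound 4 can be read. Compound 2 stays where it stood, now with compound 4 beside it: the limit of > 100000 nM in this assay, at which 3 of the 4 values shown sit.

The compounds shown leave open whether (4-chloro-3-fluorophenyl)amino in place of hydroxy on a carbonyl carbon changes the read-out at all.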